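A Larger Aromatic Group on a Weak Inhibitor Series

The compounds below may be only part of what the source reports. "The series", "measured", "known", "first", "only" and "open" are said of these compounds alone.

Compound 1 `CCOC(=O)C1=Cc2ccccc2OC1(OCc1cc(-c2ccc(OC)cc2)no1)C(F)(F)F` belongs to a small set of three measured compounds built on a shared core, each carrying a different aromatic group on a five-membered ring. In a functional assay on DU-145 cells (Homo sapiens) for inhibition, read by MTT assay, with a stated time of 24 h (a higher number here means a weaker inhibitor, a lower number a stronger inhibitor), compound 1 gives > 150000 nM, which is a limit of the assay and not a measured number. Compound 2 `CCOC(=O)C1=Cc2ccccc2OC1(OCc1cn(-c2ccc(C)cc2)nn1)C(F)(F)F` gives 30200 nM in this assay. Compound 3 `O=C(O)C1=Cc2ccccc2OC1(OCc1cc(-c2ccc([N+](=O)[O-])cc2)no1)C(F)(F)F` gives 100000 nM in this assay. Compound 1 therefore stands at the weak end of what has been measured, at the limit of > 150000 nM in this assay, at which 1 of the 3 values shown sits.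

Compound 4 `CCOC(=O)C1=Cc2ccccc2OC1(OCc1cc(-c2ccc3ccccc3c2)no1)C(F)(F)F` has not yet been measured. It differs from compound 1 in one place: naphthalen-2-yl in place of 4-methoxyphenyl on an aromatic carbon. For the measured compounds named here, no measured pair of compounds differs in only one place, so the size of such a step can only be estimated. The step of an at least 1.6-fold lower number from compound 1 to compound 4 (0.22 log units; that floor lies within the scatter) is expected to be a modest gain in this assay, not much beyond the usual scatter. For compound 4 the estimated value is 90000 nM, with a range from 25000 nM to 200000 nM, and a real chance that only a limit is again reported.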

Compound 4, half-maximal inhibitory concentration: 71800 nM
Compound 4: the middle estimate sits 1.3-fold (0.10 log units) above what was measured, and the stated range covers the measured number.
By their numbers in this assay, from the lowest: compound 2; then compounds 4 and 3 (each within the scatter of the next). At a limit, above all of these: compound 1.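

For the compounds shown here, this is the first change in one place that can be read. At this position, on an aromatic carbon next to the ring nitrogen, naphthalen-2-yl in place of 4-methoxyphenyl gives an at least 2.0-fold lower number from compound 1 to compound 4 (0.31 log units; beyond the scatter). The change adds a second six-membered aromatic ring and removes the one hydrogen-bond acceptor of the leaving group, so that acceptor is not needed for compound 4 to reach 71800 nM in this assay. The full size of the step remains unknown, because one end of it is a limit of the assay, not a measured number: the limit of > 150000 nM in this assay, at which 1 of the 4 values shown sits.

The compounds shown do not separate the effect of the added ring from that of losing the methoxy oxygen. On these data alone, a plain phenyl group at this position would be the direct comparison, and how it would fall remains open.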